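Benzylaminopurine ribosides on HL-60: weighing an added hydroxyl

The source may report more compounds than this note shows. Statements on the series, on what has been measured and on what is new or still open speak of the compounds shown alone.

Measured so far:
compound 1, `COc1cccc(CNc2ncnc3c2ncn3[C@@H]2O[C@H](CO)[C@@H](O)[C@H]2O)c1`, 4900 nM
compound 2, `OC[C@H]1O[C@@H](n2cnc3c(NCc4ccc(F)c(Cl)c4)ncnc32)[C@H](O)[C@@H]1O`, 3500 nM

Compound 1 carries a 3-methoxyphenyl on the benzylic carbon; compound 2 carries 3-chloro-4-fluorophenyl in its place. In a functional assay on HL-60 cells (Homo sapiens) for antiproliferative activity, with a stated time of 72 h (a higher number here means a weaker inhibitor, a lower number a stronger inhibitor), compound 1 gives 4900 nM, and in this assay compound 2 gives 3500 nM. Going by the values given here, the single measured step, a 1.4-fold lower number from compound 1 to compound 2 (0.15 log units; within the scatter), so the two aryl groups cannot be told apart on these numbers, and compound 2 stands together with compound 1 rather than apart from it.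

Compound 3, `COc1cccc(CNc2ncnc3c2ncn3[C@@H]2O[C@H](CO)[C@@H](O)[C@H]2O)c1O`, has not yet been measured. The change is 2-hydroxy-3-methoxyphenyl in place of 3-chloro-4-fluorophenyl on a saturated chain carbon bound to a nitrogen on an aromatic ring. The only step that bears on it is the aryl swap a 1.4-fold lower number from compound 1 to compound 2 (0.15 log units; within the scatter), which was within the scatter, so the aryl group has so far shown no effect that can be measured here. Among the compounds with values here, compound 3 is close to compound 1 in its aryl group, with one extra hydroxyl, and no measured step shows what such an addition does. The expectation is therefore a step of a 1.3-fold higher number from compound 2 to compound 3 (0.11 log units; within the scatter), not beyond the scatter. Compound 3 is estimated at 4500 nM, with a range from 1800 nM to 12000 nM.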

Compound 3, half-maximal inhibitory concentration: 150 nM
Estimate against measurement, compound 3: 30-fold (1.48 log units) above; the measured number lies below the stated range.
By their numbers in this assay, from the lowest: compound 3; then compounds 2 and 1 (each within the scatter of the next).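

In this assay, going by these compounds alone, the aryl group on a saturated chain carbon bound to a nitrogen on an aromatic ring can carry a large effect after all: hydroxy in place of hydrogen on an aromatic carbon gives a 33-fold lower number from compound 1 to compound 3 (1.51 log units; beyond the scatter), and the full exchange of aryl groups gives a 23-fold lower number from compound 2 to compound 3 (1.37 log units; beyond the scatter), whereas the only earlier step stayed within the scatter. Compound 1 and compound 3 differ in that one hydroxy alone, so this single addition to the 3-methoxyphenyl group accounts for the whole of the first step, and the series now has one clear sensitivity where before it had none. Nothing available here gives any measured property or other data that would explain the size of this step.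

On these data alone, it remains open whether the hydroxy needs the methoxy group that accompanies it in compound 3, or whether it would have a comparable effect alone or on the 3-chloro-4-fluorophenyl group of compound 2. As far as these compounds go, it is equally open whether an amine or a carboxylic acid in place of the hydroxy on that aromatic carbon would keep the number near that of compound 3 or return it to that of compound 1.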